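The source may hold more compounds than are shown below. What is called first, only, known or untested is meant among the compounds shown, and "the series" means these compounds.

Measured compounds in a functional assay on SMMC-7721 cells (Homo sapiens) for cytotoxicity, read by MTT assay, with a stated time of 4 days; on this read-out higher numbers stand for weaker inhibition and lower numbers for stronger inhibition:
- compound 1 `C=C1C[C@]23C[C@@]1(O)CC[C@@H]2c1cccc(C)c1[C@@H]3Cn1cc(-c2ccc(C)cc2)nn1`: > 20000 nM
- compound 2 `C=C1C[C@]23C[C@@]1(O)CC[C@H]2c1cc(Br)c(O)c(C)c1[C@@H]3Cn1cc(-c2ccc(C)cc2)nn1`: > 20000 nM
- compound 3 `Cc1ccc(S(=O)(=O)Oc2ccc3c(c2C)[C@H](Cn2cc(-c4ccc(C(F)(F)F)cc4)nn2)[C@@]24CC(=O)[C@@](C)(CC[C@@H]32)C4)cc1`: > 20000 nM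

Compound 1 gives only a limit in this assay, > 20000 nM. Compound 2 likewise returns a limit, > 20000 nM. Compound 3 also stops at a limit, > 20000 nM. Going by the values given here, no measured pair differs in a single place, so no step within the set can be sized; all that can be said is that every value shown sits at the same point, namely (the limit of > 20000 nM in this assay, at which 3 of the 3 values shown sit), and compound 1 stands exactly there, with nothing in the set resolved below it.

The unmeasured compound 4 `C=C1C[C@]23C[C@@]1(O)CC[C@@H]2c1cccc(C)c1[C@@H]3Cn1cc(-c2ccc(Cl)cc2)nn1` differs from compound 1 by chloro in place of methyl on an aromatic carbon, the same difference read one bond further out being 4-methylphenyl to 4-chlorophenyl. Among the compounds with values here, with no measured step to lean on, and with compound 1 itself only a limit at > 20000 nM, the working expectation is that the step from compound 1 to compound 4 in this assay brings no change beyond the scatter, and most likely another limit. The estimated step is a step that the limit leaves unreadable from compound 1 to compound 4, and for compound 4 the estimate in this assay is 30000 nM, in a range from 12000 nM to 100000 nM.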

Compound 4, half-maximal inhibitory concentration: > 20000 nM
Compound 4 gave a limit, no number; the forecaster's own chance of this, stated with the estimate: 85%; the middle value lies beyond the limit too.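

In this assay compound 4 gives only a limit (> 20000 nM). Compound 1 is likewise a limit (> 20000 nM), and no new step can be read from this pair. The compounds shown leave open whether chloro in place of methyl changes the read-out at all, and what a resolved value in this series would look like, because every value stands at one point: the limit of > 20000 nM in this assay, at which 4 of the 4 values shown sit.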